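Adding a chloro group to a weak thiazolidinone inhibitor

The source may hold more compounds than are shown below. What is called first, only, known or untested is meant among the compounds shown, and "the series" means these compounds.

The series shares one core, shown by compound 1 `O=C1CS/C(=N\c2csc(-c3ccccc3)c2)N1`. In a functional assay on HT-29 cells (Homo sapiens) for cytotoxicity, read by MTT assay, with a stated time of 72 h (a higher number here means a weaker inhibitor, a lower number a stronger inhibitor), compound 1 gives only a limit of the assay, > 50000 nM. Compound 2 `COc1cccc(N2C(=O)CS/C2=N\c2csc(-c3ccccc3)c2)c1` carries a 3-methoxyphenyl group on the amide-type nitrogen of the ring, and in this assay compound 2 gives 38300 nM. For the measured compounds named here, this is the sole measured number in the set, the other value being a limit (the limit of > 50000 nM in this assay, at which 1 of the 2 values shown sits), so compound 2 stands as the single fixed point. The change between them, an at least 1.3-fold lower number from compound 1 to compound 2 (0.11 log units; that floor lies within the scatter), has a floor that lies within the scatter.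

Compound 3 `COc1cccc(N2C(=O)CS/C2=N\c2csc(-c3ccc(Cl)cc3)c2)c1` differs from compound 2 in one place: chloro in place of hydrogen on an aromatic carbon. Going by the values given here, no measured step touches this phenyl ring; the only measured step concerns the amide-type nitrogen, so nothing here shows what a chloro at this position does. The expectation is therefore a step within the scatter, a 1.1-fold lower number from compound 2 to compound 3 (0.04 log units; within the scatter), with no direction claimed. In this assay compound 3 is expected to give about 35000 nM, between 12000 nM and 100000 nM.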

Compound 3, half-maximal inhibitory concentration: 24600 nM
Estimate against measurement, compound 3: 1.4-fold (0.15 log units) above; the measured number falls inside the stated range.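

For the compounds shown here, this is the first measured step on the phenyl ring, since the earlier step concerned only the amide-type nitrogen. In this assay, phenyl to 4-chlorophenyl gives a 1.6-fold lower number from compound 2 to compound 3 (0.19 log units; within the scatter), so the two compounds cannot be told apart by this measurement, and swapping hydrogen for chloro at this position shows neither a real gain nor a real loss. The position therefore accepts a chloro group without a change beyond the scatter, but nothing shown here speaks to why the step has this size.

The compounds shown leave open whether a different group at this same position, such as an amine, a carboxylic acid or a longer carbon chain, would move the number beyond the scatter, as a single chloro does not. They also leave open whether chloro would behave the same way at another place on this phenyl ring, or alongside something other than the 3-methoxyphenyl group on the amide-type nitrogen, since one step on one compound pair cannot establish a pattern for the series.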